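The source may hold more compounds than are shown below. What is called first, only, known or untested is meant among the compounds shown, and "the series" means these compounds.

Compound 2 `COc1ccc2c(=O)c(/C=C/C(=O)Nc3ccccc3C)coc2c1` and compound 1 `COc1ccc2c(=O)c(/C=C/C(=O)NCc3ccccc3)coc2c1` were both examined in a functional assay on A549 cells (Homo sapiens) for inhibition, read by MTT assay, with a stated time of 48 h; a higher number here means a weaker inhibitor, a lower number a stronger inhibitor. In this assay compound 1 gives 11800 nM. In this assay, within the data shown here, compound 2 gives 23400 nM, the highest of the two numbers so far, yet the only step that reaches it, a 2.0-fold higher number from compound 1 to compound 2 (0.30 log units; within the scatter), stays within the scatter, so the two compounds cannot be told apart on this reading. Compound 3 `COc1ccc2c(=O)c(/C=C/C(=O)Nc3ccc(F)cc3)coc2c1` has not yet been measured in this assay. It differs from compound 2 in one place: 4-fluorophenyl in place of 2-methylphenyl on an amide-type nitrogen. Among the measured compounds shown here, no measured step exchanges one substituted phenyl on the amide-type nitrogen for another; the single step that has been measured, from benzyl to 2-methylphenyl, moved the number by less than the scatter. With nothing further to draw on, the expected step of a 1.2-fold lower number from compound 2 to compound 3 (0.07 log units; within the scatter) is one that stays within the scatter, in no particular direction. Compound 3 is therefore expected to give about 20000 nM in this assay, with a range from 7000 nM to 60000 nM that reflects both the scatter and the absence of a directly comparable step.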

Compound 3, half-maximal inhibitory concentration: 26800 nM
Compound 3: middle estimate off by 1.3-fold (0.13 log units), on the low side; the measured number falls inside the stated range.
By their numbers in this assay, from the lowest: compounds 1, 2 and 3 (each within the scatter of the next, the first and the last beyond it).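

Among these compounds, for the first time, one substituted phenyl replaces another on the amide-type nitrogen, and in this assay this exchange (a 1.1-fold higher number from compound 2 to compound 3 (0.06 log units; within the scatter)) leaves 2-methylphenyl and 4-fluorophenyl indistinguishable at this position. Among the compounds shown here, the exchange of benzyl for 4-fluorophenyl (a 2.3-fold higher number from compound 1 to compound 3 (0.36 log units; beyond the scatter)) gives the first step here that passes the scatter, though only modestly, whereas the exchange of benzyl for 2-methylphenyl (a 2.0-fold higher number from compound 1 to compound 2 (0.30 log units; within the scatter)) does not, so the two substituted phenyl groups do not separate cleanly from benzyl as a class. No evidence on hand accounts for this small difference between the two exchanges.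

The compounds shown leave open whether an unsubstituted phenyl on the same nitrogen would read like compound 2 and compound 3, which would indicate whether the methyl or the fluorine matters at all. They also leave open whether a different kind of group, such as a carboxylic acid or an amine on the phenyl ring, or a longer chain joining the ring to the amide-type nitrogen, would move the number further than any step seen so far.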